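Benzyl for dichlorobenzyl swap, cell growth inhibition notes

This account rests on a few compounds, and the source may have more. Where it says the series, first, only, none or still open, it means among the compounds named here.

Three compounds have numbers in a functional assay on I10 cells (Mus musculus) for inhibition, read by MTT assay, with a stated time of 72 h; on this read-out higher numbers stand for weaker inhibition and lower numbers for stronger inhibition. Compound 1 `C=CCc1ccc(O)c(-c2ccc(OCc3ccccc3)c(CC=C)c2)c1` gives 29800 nM. Compound 2 `C=CCc1ccc(O)c(-c2ccc(OCc3c(Cl)cccc3Cl)c(CC=C)c2)c1` gives 16600 nM, and compound 3 `C=CCc1ccc(OCc2c(Cl)cccc2Cl)c(-c2ccc(O)c(CC=C)c2)c1` gives 17200 nM. Compound 2 and compound 3 are built from the same atoms joined differently; the difference between the two cores is not broken down here, and their two values lie within the scatter of each other.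

Compound 1 comes from compound 2 by a single change, (phenyl in place of 2,6-dichlorophenyl on a saturated chain carbon bound to an oxygen on an aromatic ring). That change reads as a 1.8-fold higher number from compound 2 to compound 1 (0.25 log units; within the scatter), so it sits inside the usual spread of repeats.

Compound 4 `C=CCc1ccc(OCc2ccccc2)c(-c2ccc(O)c(CC=C)c2)c1` awaits measurement in this assay. It comes from compound 3 by phenyl in place of 2,6-dichlorophenyl on a saturated chain carbon bound to an oxygen on an aromatic ring, the same change at the same place as the one already measured, making two occurrences in all. Going by the values given here, because the only precedent is a 1.8-fold higher number from compound 2 to compound 1 (0.25 log units; within the scatter), the expected step is a 1.7-fold higher number from compound 3 to compound 4 (0.24 log units; within the scatter). Compound 4 is therefore estimated at 30000 nM, with a plausible range from 15000 nM to 60000 nM, the width reflecting that one precedent within scatter is thin ground.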

Compound 4, half-maximal inhibitory concentration: 21800 nM
Beside the measured number, compound 4's estimate is 1.4-fold (0.14 log units) above it, and the stated range covers the measured number.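

The swap of 2,6-dichlorobenzyl to benzyl in this assay reads as a 1.3-fold higher number from compound 3 to compound 4 (0.10 log units; within the scatter). Set beside the earlier occurrence, the two steps do not differ: the same change on two cores in this assay, a 1.8-fold higher number (0.25 log units; within the scatter) from compound 2 to compound 1 and a 1.3-fold higher number (0.10 log units; within the scatter) from compound 3 to compound 4, 1.4-fold (0.15 log units) apart, within the scatter of two such steps. This shows that, on these two cores, the swap moves the number by no more than the usual spread of repeats, and that the result on one core gave no misleading picture of the other; it does not show that 2,6-dichlorophenyl and phenyl differ on either core, and two cores are too few to set a rule for the series.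

The compounds shown span only phenyl and 2,6-dichlorophenyl at this place, so it remains open whether a group of another kind there, such as an amine or a carboxylic acid, would move the number beyond the scatter. Going by these compounds, it is equally open whether a longer chain between the oxygen and the ring would do so.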